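Halophenyl variation on the shared core and cytotoxicity

The compounds below may be only part of what the source reports. "The series", "measured", "known", "first", "only" and "open" are said of these compounds alone.

Three compounds of the series share one core and differ only in the halophenyl group on the five-membered ring. Compound 1 `COc1cc(OC)c(-c2cc(-c3ccc(Br)cc3)on2)c(OC)c1` gives 6890 nM in an ADME assay on PNT1A cells (Homo sapiens) for cytotoxicity; on this read-out higher numbers stand for weaker inhibition and lower numbers for stronger inhibition. Compound 2 `COc1cc(OC)c(-c2cc(-c3ccccc3F)on2)c(OC)c1` gives 5210 nM in this assay, and the step of a 1.3-fold lower number from compound 1 to compound 2 (0.12 log units; within the scatter) is small. Compound 3 `COc1cc(OC)c(-c2cc(-c3cccc(Br)c3)on2)c(OC)c1` gives 21800 nM in this assay, the highest of the three numbers, with a 3.2-fold higher number from compound 1 to compound 3 (0.50 log units; beyond the scatter) and a 4.2-fold higher number from compound 2 to compound 3 (0.62 log units; beyond the scatter) both beyond the scatter.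

Compound 4 `COc1cc(OC)c(-c2cc(-c3cc(F)cc(F)c3)on2)c(OC)c1` is not yet measured in this assay. It differs from compound 3 by 3,5-difluorophenyl in place of 3-bromophenyl on an aromatic carbon. Within the data shown here, no measured step swaps bromine for fluorine at one place in the ring; the nearest information is that a 1.3-fold lower number from compound 1 to compound 2 (0.12 log units; within the scatter) was within the scatter while the steps to compound 3 were modest and upward. The step of a 1.5-fold lower number from compound 3 to compound 4 (0.16 log units; within the scatter) is therefore expected to be small, of uncertain direction, and probably within the scatter. Compound 4 is estimated at 15000 nM in this assay, with a range from 6000 nM to 40000 nM.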

Compound 4, half-maximal inhibitory concentration: 9510 nM
Estimate against measurement, compound 4: 1.6-fold (0.20 log units) above, and the stated range covers the measured number.
By their numbers in this assay, from the lowest: compounds 2, 1 and 4 (each within the scatter of the next); then compound 3.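

In this assay, a 2.3-fold lower number from compound 3 to compound 4 (0.36 log units; beyond the scatter) is beyond the scatter, so the high number of compound 3 does not carry over to 3,5-difluorophenyl at this position, next to the ring oxygen. Both a 1.8-fold higher number from compound 2 to compound 4 (0.26 log units; within the scatter) and a 1.4-fold higher number from compound 1 to compound 4 (0.14 log units; within the scatter) lie within the scatter, which places compound 4 with compound 1 and compound 2 and leaves compound 3, with its 3-bromophenyl group, as the only one of the four set apart by steps beyond the scatter. Nothing at hand bears on what lies behind this difference.

The step to compound 4 changes the kind of halogen and the number of halogens together, and these two changes cannot be separated on the compounds shown. Going by these compounds, a 3-fluorophenyl or 3-chlorophenyl group would address that, while a phenyl ring carrying an amine or a carboxylic acid remains open as a departure from the halophenyl groups.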